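The source may report more compounds than this note shows. Statements on the series, on what has been measured and on what is new or still open speak of the compounds shown alone.

Within the data shown here, compound 2 `CN1CCC[C@H]1COc1cncc(-c2cccnc2)c1` gives 0.27 nM in an assay on membranes from brain for binding affinity to Neuronal acetylcholine receptor; alpha4/beta2 (Rattus norvegicus) (a lower number here means a stronger inhibitor, a higher number a weaker inhibitor), the highest of the two numbers known so far; compound 1 `CN1CCC[C@H]1COc1cncc(-c2ccc(Cl)cc2)c1` gives 0.082 nM, and the step of a 3.3-fold higher number from compound 1 to compound 2 (0.52 log units; beyond the scatter) was modest but beyond the scatter. Compound 3 `CN1CCC[C@H]1COc1cncc(-c2cccs2)c1` differs from compound 2 by thiophen-2-yl in place of pyridin-3-yl on an aromatic carbon. Among the measured compounds shown here, only that one step bears on this change, and it concerns a different pair of rings, so the step from compound 2 to compound 3 is expected to be small, at most a somewhat lower number, a 1.8-fold lower number from compound 2 to compound 3 (0.26 log units; within the scatter). Compound 3 is therefore estimated at 0.15 nM, with a range from 0.05 nM to 0.5 nM.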

Compound 3, inhibition constant: 0.31 nM
Compound 3: the middle estimate sits 2.1-fold (0.32 log units) below what was measured; the measured number falls inside the stated range.
By their numbers in this assay, from the lowest: compound 1; then compounds 2 and 3 (each within the scatter of the next).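

Replacing the six-membered pyridin-3-yl with the five-membered thiophen-2-yl on this aromatic carbon, two atoms from the ring nitrogen, does not separate the two compounds (a 1.1-fold higher number from compound 2 to compound 3 (0.06 log units; within the scatter)). Thiophen-2-yl also stands apart from 4-chlorophenyl (a 3.8-fold higher number from compound 1 to compound 3 (0.58 log units; beyond the scatter)), so compound 1 alone differs from the other two by more than the scatter. Nothing available accounts for these steps. Still open, going by these compounds, is whether unsubstituted phenyl or thiophen-3-yl would fall with compound 2 and compound 3 or with compound 1, and how an amine or a carboxylic acid on the ring would fare.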